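This account rests on a few compounds, and the source may have more. Where it says the series, first, only, none or still open, it means among the compounds named here.

Compound 1, `Cc1cc(-c2c(O)nc3cc(Cl)c([N+](=O)[O-])cc3c2OCCC2CCCCN2)cc(C(C)O)c1`, gives 63 nM in a functional assay on cells (Pituitary gland cell) for antagonist activity at Gonadotropin-releasing hormone receptor (Rattus norvegicus); a lower number here means a stronger inhibitor, a higher number a weaker inhibitor.
Compound 2, `O=[N+]([O-])c1cc2c(OCCC3CCCCN3)c(-c3cccc(Cl)c3)c(O)nc2cc1Cl`, gives 40 nM in this assay.
Compound 3, `Cc1cc(C)cc(-c2c(O)nc3cc(Cl)c(NC(=O)c4cnccn4)cc3c2OCCC2CCCCN2)c1`, gives 1.8 nM in this assay.

Among these three, compound 1 stands at the highest number. Its nearest neighbour is compound 2, reached by the step of a 1.6-fold lower number from compound 1 to compound 2 (0.20 log units; within the scatter), so the two are not separated beyond the usual scatter. Going by the values given here, compound 3, with 1.8 nM, lies well below both and is the one compound here whose gap to compound 1 is clearly beyond the scatter.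

Compound 4, `O=[N+]([O-])c1cc2c(OCCC3CCCCN3)c(-c3cccc(F)c3)c(O)nc2cc1Cl`, differs from compound 1 in one place: 3-fluorophenyl in place of 3-(1-hydroxyethyl)-5-methylphenyl on an aromatic carbon. Among the compounds with values here, the only measured step that bears on this change is a 1.6-fold lower number from compound 1 to compound 2 (0.20 log units; within the scatter), in which the same group left and a 3-chlorophenyl entered at the same aromatic carbon; compound 4 carries a 3-fluorophenyl there instead, the two differing only in the halogen. Within the data shown here, that step stayed within the scatter, and nothing among the measured compounds points to the fluorine analogue behaving otherwise. For compound 4 a step of about a 1.3-fold lower number from compound 1 to compound 4 (0.10 log units; within the scatter) from compound 1 is therefore expected, that is, no shift beyond the scatter. In this assay compound 4 is estimated at 50 nM, within a range from 20 nM to 150 nM.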

Compound 4, half-maximal inhibitory concentration: 53 nM
Compound 4: middle estimate off by 1.1-fold (0.03 log units), on the low side; low and high end bracket the measured number.
By their numbers in this assay, from the lowest: compound 3; then compounds 2, 4 and 1 (each within the scatter of the next).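

In this assay, the step of a 1.2-fold lower number from compound 1 to compound 4 (0.08 log units; within the scatter) gives a second case in which 3-(1-hydroxyethyl)-5-methylphenyl is replaced at this aromatic carbon, ortho to a 2-(piperidin-2-yl)ethoxy group and ortho to a hydroxy group, without a shift beyond the scatter. Going by these compounds alone, the step of a 1.3-fold higher number from compound 2 to compound 4 (0.12 log units; within the scatter) adds a comparison the earlier compounds did not offer, fluoro in place of chloro on an aromatic carbon, and it shows that these two halogens are not told apart by this measurement. Nothing among the data given accounts for why these exchanges leave the number within the scatter.

From the compounds shown here alone, the three compounds with a substituent exchange at this carbon carry only these aryl groups, so it remains open whether an amine, a carboxylic acid or a longer chain on the phenyl ring would move the number beyond the scatter. Going by these compounds, it also remains open whether the same exchanges would stay within the scatter on the background of compound 3, which differs from compound 4 in more than one place.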